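The source may report more compounds than this note shows. Statements on the series, on what has been measured and on what is new or still open speak of the compounds shown alone.

Working notes on a series sharing one core, followed in a functional assay on brain (Rattus norvegicus, strain Wistar) for inhibition; a higher number here means a weaker inhibitor, a lower number a stronger inhibitor. Compound 1 (`CCCCOc1ccc(-c2c(C)[nH]c(=O)n2C2CCCCC2)cc1`) gives 13900 nM, compound 2 (`CCCCCCCc1ccc(-c2c(C)[nH]c(=O)n2C2CCCCC2)cc1`) gives 8700 nM, and compound 3 (`CCCCCCCCOc1ccc(-c2c(C)[nH]c(=O)n2C2CCCCC2)cc1`) gives 8500 nM. Compound 2 shows no separation from either of the other two. The steps that touch it are a 1.6-fold lower number from compound 1 to compound 2 (0.20 log units; within the scatter) and a 1.0-fold lower number from compound 2 to compound 3 (0.01 log units; within the scatter), both within the scatter.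

The next structure is compound 4 (`CCCCCCCCCCCCCCCCCCc1ccc(-c2c(C)[nH]c(=O)n2C2CCCCC2)cc1`), which differs from compound 2 by undecyl in place of hydrogen on a saturated chain carbon, seven bonds along the chain from an aromatic carbon. The closest measured precedent is another chain set in place of hydrogen, a 1.6-fold lower number from compound 1 to compound 3 (0.21 log units; within the scatter), also within the scatter. The exchange of one chain for another in a 1.0-fold lower number from compound 2 to compound 3 (0.01 log units; within the scatter) likewise gives no step beyond the scatter. Among the measured compounds shown here, no measured compound carries a chain as long as the one in compound 4, so this change lies outside the measured range and the estimate needs a wide margin.

Nothing in these steps points to a move beyond the scatter in this assay, in either direction. The estimated step is a 1.2-fold lower number from compound 2 to compound 4 (0.09 log units; within the scatter), and no step beyond the scatter is expected. For compound 4 the expected value is 7000 nM, with an estimated range of 2500 nM to 20000 nM.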

Compound 4, half-maximal inhibitory concentration: > 100000 nM
Compound 4 ended at the assay's limit (the forecaster's own chance of this, stated with the estimate: 12%); at least 14-fold (1.15 log units) between middle value and limit.
By their numbers in this assay, from the lowest: compounds 3, 2 and 1 (each within the scatter of the next). At a limit, above all of these: compound 4.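

In this assay, among the compounds shown here, undecyl in place of hydrogen on a saturated chain carbon, seven bonds along the chain from an aromatic carbon, gives the only step beyond the scatter: an at least 11-fold higher number from compound 2 to compound 4 (1.06 log units; beyond the scatter). The value of compound 4, > 100000 nM, is a limit of the assay and not a number: the limit of > 100000 nM in this assay, at which 1 of the 4 values shown sits.

For the compounds shown here, the earlier exchanges gave no separation, as in a 1.6-fold lower number from compound 1 to compound 2 (0.20 log units; within the scatter) and in a 1.0-fold lower number from compound 2 to compound 3 (0.01 log units; within the scatter), so heptyl and octyloxy on the aromatic carbon showed no sign that this position has an end to what it accepts, and compound 4 is the first to show one.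

Still open, going by these compounds, is the chain length at which the number leaves the range of compound 2 and compound 3, a point that a decyl or a dodecyl group on the aromatic carbon would help to fix. Going by these compounds alone, also open is whether length alone carries the step, which a chain as long as the one in compound 4 but ending in a carboxylic acid or an amine would test.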